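The source may hold more compounds than are shown below. What is called first, only, known or untested is meant among the compounds shown, and "the series" means these compounds.

In an ADME assay on MDBK cells (Bos taurus) for cytotoxicity, read by MTT assay, with a stated time of 96 h (on this read-out higher numbers stand for lower toxicity in this test and lower numbers for higher toxicity in this test), compound 1 (`COc1ccc(-c2nc3cc([N+](=O)[O-])ccc3[nH]2)c(OC)c1`) gives > 100000 nM, which is a limit of the assay and not a number. Compound 2 (`CC(=O)Nc1ccc(-c2nc3ccccc3[nH]2)cc1`) gives > 100000 nM, likewise only a limit. Compound 2 thus stands at the limit of > 100000 nM in this assay, at which 2 of the 2 values shown sit.

Compound 3 (`CC(=O)Nc1ccc(-c2nc3cc([N+](=O)[O-])ccc3[nH]2)cc1`) differs from compound 2 by one change: nitro in place of hydrogen on an aromatic carbon. Among the compounds with values here, no measured pair isolates this change, so its size in this assay can only be expected. The likeliest outcome is no step beyond the scatter, with some room toward lower numbers. Compound 1 also carries a nitro group and still gives > 100000 nM, again a limit, and this supports the expectation. The expected step is an at least 1.3-fold lower number from compound 2 to compound 3 (0.12 log units; that floor lies within the scatter). For compound 3 the estimated value is 75000 nM, with an expected range from 25000 nM to 100000 nM.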

Compound 3, half-maximal cytotoxic concentration: > 100000 nM
Compound 3 was reported as a limit; the forecaster's own chance of this, stated with the estimate: 65%; middle value at least 1.3-fold (0.12 log units) away from the limit.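

Compound 2 and compound 3 both stand at a limit of the assay and not at a number, so no step can be read between them. The compounds shown leave open at what concentration any of them would become toxic to these cells, and whether nitro in place of hydrogen changes that concentration.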